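The source may report more compounds than this note shows. Statements on the series, on what has been measured and on what is new or still open speak of the compounds shown alone.

Compound 1 `COc1ncnc2c1c(-c1ccsc1)cn2[C@@H]1O[C@H](CO)[C@@H](O)[C@H]1O` is the reference point of the series. In a functional assay on HCT-116 cells (Homo sapiens), read by MTT assay, with a stated time of 72 h (a lower number here means a stronger inhibitor, a higher number a weaker inhibitor), compound 1 gives 120 nM, the lowest of the two numbers shown. Compound 3 `Cc1ncnc2c1c(-c1ccsc1)cn2[C@@H]1O[C@H](CO)[C@@H](O)[C@H]1O` gives 460 nM in this assay, and the step is a 3.8-fold higher number from compound 1 to compound 3 (0.58 log units; beyond the scatter). Compound 2 `COc1nc(N)nc2c1c(-c1ccsc1)cn2[C@@H]1O[C@H](CO)[C@@H](O)[C@H]1O` is reported in this assay only as a limit of the assay, > 20000 nM, one of the values at the limit noted in the limit of > 20000 nM in this assay, at which 1 of the 3 values shown sits; the change there is an at least 160-fold higher number from compound 1 to compound 2 (2.22 log units; beyond the scatter).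

Compound 4 `C#Cc1cn([C@@H]2O[C@H](CO)[C@@H](O)[C@H]2O)c2ncnc(OC)c12` has not been measured. It differs from compound 1 by ethynyl in place of thiophen-3-yl on an aromatic carbon. Within the data shown here, both measured steps concern the six-membered part of the shared core, not the aromatic carbon of the five-membered ring that carries the substituent replaced here, so neither bears directly on this change; they show only that the number in this assay can move modestly or very far with a single change. A smaller group replacing a thiophene ring is expected to cost some potency, so a modest rise, a 2.9-fold higher number from compound 1 to compound 4 (0.46 log units; beyond the scatter), is estimated. Compound 4 is expected to give about 350 nM in this assay, within 70 nM to 2500 nM.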

Compound 4, half-maximal inhibitory concentration: 4060 nM
For compound 4 the middle estimate is 12-fold (1.06 log units) below the measured one, and the stated range ends below it.
By their numbers in this assay, from the lowest: compound 1; then compound 3; then compound 4. At a limit, above all of these: compound 2.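

Among these compounds, the first change at the aromatic carbon of the five-membered ring carrying thiophen-3-yl gives, in this assay, a 34-fold higher number from compound 1 to compound 4 (1.53 log units; beyond the scatter). This position is therefore sensitive to replacement, and swapping thiophen-3-yl for ethynyl costs far more than the methoxy change, which gives a 3.8-fold higher number from compound 1 to compound 3 (0.58 log units; beyond the scatter). The data shown give no measured basis for explaining the size of the new step.

With ethynyl as the only replacement at this position, the step cannot be divided between the loss of the thiophene ring and the entry of the triple bond. Going by these compounds, whether a phenyl or furan-3-yl ring would hold the number near that of compound 1, and how a simple ethyl or an amine would compare, remains open.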